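A Second Fluoro Group on the Shared Core

A few compounds are considered here, and "the series" means these few. Any claim that something is new, unique, unknown or untested is made for them only; others in the source may bear on it.

In an ADME assay on the whole organism with Oryza sativa as the target, tested at 10 uM (a lower number here means a stronger effect, a higher number a weaker effect of the compound at the concentration tested), compound 1 `Cc1cccc(NC(=O)N[C@@H](C)c2ccccc2)c1` gives 100%. Compound 2 `CC(=O)c1cccc(NC(=O)N[C@@H](C)c2ccccc2)c1` gives 94% in this assay, and compound 3 `C[C@H](NC(=O)Nc1cccc(F)c1)c1ccccc1` gives 88%. Compound 3 therefore holds the lowest of the three numbers, yet compound 2 stands within the scatter of it; only compound 1 lies beyond the scatter, as a number 12 percentage points lower from compound 1 to compound 3 (beyond the scatter) shows, while a number 6 percentage points lower from compound 1 to compound 2 (within the scatter) and a number 6 percentage points lower from compound 2 to compound 3 (within the scatter) stay within it.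

Compound 4 `C[C@H](NC(=O)Nc1cccc(F)c1F)c1ccccc1` differs from compound 3 by fluoro in place of hydrogen on an aromatic carbon. Among the measured compounds shown here, no measured step places fluoro in place of hydrogen, so the bearing of the three steps is indirect. For the measured compounds named here, the one step beyond the scatter, a number 12 percentage points lower from compound 1 to compound 3 (beyond the scatter), brought a fluoro group onto the ring, whereas the step with fluoro in place of acetyl, a number 6 percentage points lower from compound 2 to compound 3 (within the scatter), was within the scatter. On that footing a small downward step at most is expected, a number 4 percentage points lower from compound 3 to compound 4 (within the scatter), and possibly none beyond the scatter. Compound 4 is accordingly estimated at 84%, within a range of 72% to 96%.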

Compound 4, a percentage reported as activity, at one concentration (the size of the read-out at that concentration, not a potency): 100%
Estimate against measurement, compound 4: 16 percentage points below; the measured number lies above the stated range.
By their numbers in this assay, from the lowest: compounds 3, 2, 1 and 4 (each within the scatter of the next, the first and the last beyond it).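

At this position, on an aromatic carbon ortho to a fluoro group, fluoro in place of hydrogen gives in this assay a number 12 percentage points higher from compound 3 to compound 4 (beyond the scatter) and so shows that the position is not indifferent to this change. Among the compounds shown here, the only earlier step beyond the scatter, a number 12 percentage points lower from compound 1 to compound 3 (beyond the scatter), also brought in a fluoro group but ran in the opposite direction, so across compounds 1, 3 and 4 the arrival of a fluoro group does not by itself set the direction of the step. Nothing at hand explains why the second fluoro group acts as it does.

The compounds shown leave open whether a chloro or a methoxy group at this same position would follow the step seen with fluoro. They also leave open whether the step depends on the first fluoro group, since a single fluoro group at this position on the shared core does not appear among them.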